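From methoxycarbonyl to ethoxycarbonyl in the series

The source may hold more compounds than are shown below. What is called first, only, known or untested is meant among the compounds shown, and "the series" means these compounds.

Measured so far:
- compound 1 `CC(=O)N(C)CC#CCN1CCCC1`: > 10 mg/kg (a limit)
- compound 2 `COC(=O)N(C)CC#CCN1CCCC1`: > 10 mg/kg (a limit)

In a functional assay on the whole organism for antagonist activity, with Mus musculus as the target (a higher number here means that more compound is needed for the effect, a lower number that less compound is needed), compound 2 gives > 10 mg/kg, which is a limit and not a number. Going by the values given here, the series so far offers only (the limit of > 10 mg/kg in this assay, at which 2 of the 2 values shown sit). Compound 3 `CCOC(=O)N(C)CC#CCN1CCCC1` follows from compound 2 by methyl in place of hydrogen on a saturated chain carbon bound to an oxygen next to a carbonyl group, that is, methoxy to ethoxy. Among the compounds with values here, the single measured step is a step that the two limits leave unreadable from compound 1 to compound 2. It concerns another change and has no readable size, so it gives no measure for this one. The expectation therefore rests on that step and on the limit shared by compound 1 and compound 2, and no direction can be drawn from them. A further limit reading in this assay is expected. The estimated step is a step that the limit leaves unreadable from compound 2 to compound 3. For compound 3 the expected value is 20 mg/kg, with an estimated range from 8 mg/kg to 60 mg/kg.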

Compound 3, dose for half-maximal effect: > 100 mg/kg
Compound 3: only a limit was reported; the forecaster's own chance of this, stated with the estimate: 80%; middle value at least 5.0-fold (0.69 log units) from the limit.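

In this assay compound 3 gives > 100 mg/kg, a limit and not a number. Going by these compounds alone, compound 2 gives > 10 mg/kg, also a limit, so no step among compound 1, compound 2 and compound 3 can be read. The compounds shown leave open whether methoxy to ethoxy changes the dose for half-maximal effect at all.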